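The source may hold more compounds than are shown below. What is called first, only, known or untested is meant among the compounds shown, and "the series" means these compounds.

Of the compounds shown here, two have been measured in a functional assay on NCI-H460 cells (Homo sapiens) for antiproliferative activity, read by CCK-8 assay, with a stated time of 72 h, tested at 2 uM; on this read-out lower numbers stand for a weaker effect and higher numbers for a stronger effect at the one concentration tested. Compound 1 `CC(C)n1cnc2c(NCc3ccc(C(=O)Nc4ccccc4N)cc3)nc(Cl)nc21` gives 54.2%. Compound 2 `Nc1ccccc1NC(=O)c1ccc(CNc2nc(Cl)nc3c2ncn3Cc2ccccc2)cc1` gives 43.8%. Going by the values given here, the one step between them, a number 10.4 percentage points lower from compound 1 to compound 2 (beyond the scatter), is the only measured step so far, and it places compound 2 at the lower of the two numbers, with compound 1 the higher one by a margin beyond the scatter.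

Compound 3 `CCCn1cnc2c(NCc3ccc(C(=O)Nc4ccccc4N)cc3)nc(Cl)nc21` has not yet been measured. It differs from compound 2 in one place: ethyl in place of phenyl on a saturated chain carbon bound to an aromatic nitrogen. The measured step from compound 1 to compound 2 bears directly on this change, since it swapped an isopropyl for a benzyl on the aromatic nitrogen and cost a modest amount; removing the phenyl again, leaving a propyl, runs that step partly back. Compound 3 is therefore expected to move a number 7.2 percentage points higher from compound 2 to compound 3 (within the scatter), an upward step of modest size that may still fall within the scatter. On that basis compound 3 is estimated at 51%, with a range from 38% to 64%.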

Compound 3, a percentage reported as inhibition, at one concentration (the size of the read-out at that concentration, not a potency): 31%
For compound 3 the middle estimate is 20 percentage points above the measured one, outside the stated range (below it).
By their numbers in this assay, from the lowest: compound 3; then compound 2; then compound 1.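

In this assay, the step of a number 12.8 percentage points lower from compound 2 to compound 3 (beyond the scatter) shows that replacing benzyl with propyl on the aromatic nitrogen does not recover the earlier loss, but takes the number further down. The step of a number 23.2 percentage points lower from compound 1 to compound 3 (beyond the scatter) shows that this position also distinguishes between branched isopropyl and unbranched propyl, so among these three compounds the number does not follow the size of the group, with benzyl in compound 2 falling between the two smaller groups. No measurement offered here explains why the unbranched chain gives the lowest number of the three.

The compounds shown leave open whether a cyclopentyl ring or a longer chain such as butyl on the same aromatic nitrogen would stay with isopropyl or fall with propyl, and whether a phenethyl group would behave like benzyl. Each number is the size of the effect at a single concentration, so they also leave open how far these differences in effect would hold at other concentrations.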